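This account rests on a few compounds, and the source may have more. Where it says the series, first, only, none or still open, it means among the compounds named here.

Compound 3, with the structure `CC1(OC(=O)N2CCC(O[C@H]3CC[C@H](Oc4cnc(S(C)(=O)=O)cn4)CC3)CC2)CC1`, gives 123% in a functional assay on isolated protein for agonist activity at Glucose-dependent insulinotropic receptor (Rattus norvegicus), read by HTRF and cAMP accumulation; on this read-out higher numbers stand for larger maximal responses and lower numbers for smaller maximal responses. Compound 2, `CC(C)OC(=O)N1CCC(O[C@H]2CC[C@H](Oc3cnc(S(C)(=O)=O)cn3)CC2)CC1`, gives 120%, and compound 1, `Cc1nc(S(C)(=O)=O)ccc1O[C@H]1CC[C@H](OC2CCN(C(=O)OC(C)C)CC2)CC1`, gives 114%; all three numbers lie within the usual scatter of one another, so none of them can be set apart from the others. Compound 4, `C[C@@H](CF)OC(=O)N1CCC(O[C@H]2CC[C@H](Oc3cnc(S(C)(=O)=O)cn3)CC2)CC1`, differs from compound 3 by 1-(fluoromethyl)ethyl in place of 1-methylcyclopropyl on an oxygen next to a carbonyl group. Among the measured compounds shown here, the one measured step at this same oxygen, a number 3 percentage points higher from compound 2 to compound 3 (within the scatter), did not reach beyond the scatter, and no further step at this place exists. A change at this oxygen is therefore expected to leave this assay essentially where it is. Compound 4 is estimated at 120%, with a range from 108% to 132%. The expected step of a number 3 percentage points lower from compound 3 to compound 4 (within the scatter) is thus judged to stay within the scatter.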

Compound 4, largest response reached (Emax), in percent of the reference or control that the assay uses: 123%
Beside the measured number, compound 4's estimate is 3 percentage points below it; measured number inside the range.
By their numbers in this assay, from the lowest: compounds 1, 2, 3 and 4 (each within the scatter of the next).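

In this assay, the ring of 1-methylcyclopropyl gives way to the open 1-(fluoromethyl)ethyl with no change at the digits printed from compound 3 to compound 4 (within the scatter), so among these compounds a ring is not required on this oxygen. Fluoro in place of hydrogen gives a number 3 percentage points higher from compound 2 to compound 4 (within the scatter), which means the three groups at this place now shown all lie within the scatter of one another. Nothing available explains this result. Going by these compounds, it remains open whether a longer chain or an amine at this oxygen would also stay within the scatter. On these data alone, the opposite stereocentre of 1-(fluoromethyl)ethyl is equally open.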